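The source may report more compounds than this note shows. Statements on the series, on what has been measured and on what is new or still open speak of the compounds shown alone.

Compound 1 `O=S(=O)(Nc1ccc(-c2nc3ccccc3o2)cc1)c1ccc(O)cc1` and compound 2 `O=S(=O)(Nc1ccc(-c2nc3ccccc3o2)cc1)c1ccc(C(F)(F)F)cc1` share one core and differ only in the aryl group on the sulfonyl sulfur. In an ADME assay on HEK293 cells (Homo sapiens) for cytotoxicity, read by resazurin assay, with a stated time of 48 h (a higher number here means that more compound is tolerated, a lower number that less compound is tolerated), compound 1 gives > 100000 nM, which is a limit of the assay and not a number. Compound 2 gives 94000 nM in this assay. The step of an at least 1.0-fold lower number from compound 1 to compound 2 (0.02 log units; that floor lies within the scatter) is known only as a floor because the limit of > 100000 nM in this assay, at which 1 of the 2 values shown sits, caps the measurable range on the compound 1 side. For the measured compounds named here, compound 3 `Cc1cccc(S(=O)(=O)Nc2ccc(-c3nc4ccccc4o3)cc2)c1` is not yet measured in this assay. 3-methylphenyl in place of 4-hydroxyphenyl on a sulfonyl sulfur The single measured step from the same starting point, the move to trifluoromethyl, was not resolved beyond the scatter, so no shift beyond the scatter is expected here either. The step of an at least 1.1-fold lower number from compound 1 to compound 3 (0.04 log units; that floor lies within the scatter) is expected to stay within the scatter, with compound 3 estimated at 90000 nM, in the range 40000 nM to 200000 nM.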

Compound 3, half-maximal cytotoxic concentration: > 100000 nM
Compound 3: only a limit was reported; the forecaster's own chance of this, stated with the estimate: 40%; at least 1.1-fold (0.04 log units) between middle value and limit.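

In this assay compound 3 gives > 100000 nM as a limit and not a number. For the compounds shown here, compound 1 also stands at a limit, so no step between compound 1 and compound 3 can be read: the limit of > 100000 nM in this assay, at which 2 of the 3 values shown sit. From the compounds shown here alone, how far either compound lies past that limit stays open, and with it any order between them.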